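A few compounds are considered here, and "the series" means these few. Any claim that something is new, unique, unknown or untested is made for them only; others in the source may bear on it.

Measured so far:
compound 1 `COc1cc(C)cc(-c2c(-c3ccnc(-c4ccc(C(C)=O)cc4)c3)cnn2CC#N)c1`: 12%
compound 2 `COc1cc(C)cc(-c2nn(CC#N)cc2-c2ccc(-c3cccc(C(C)=O)c3)nc2)c1`: 12%

In a functional assay on HCT-15 cells (Homo sapiens) for cytotoxicity, read by sulforhodamine B assay, with a stated time of 48 h, tested at 1 uM (a higher number here means a weaker effect of the compound at the concentration tested, a lower number a stronger effect), compound 1 gives 12%. In this assay compound 2 gives 12%, level with compound 1 at the digits shown; the two values lie within the usual scatter, so no order between them can be stated. Both read-outs are low, which at the single concentration tested means a strong effect for each.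

Compound 3 `COc1cc(C)cc(-c2c(-c3ccnc(-c4ccc(N(C)C)cc4)c3)cnn2CC#N)c1` has not been measured. It differs from compound 1 in one place: dimethylamino in place of acetyl on an aromatic carbon. Going by the values given here, no pair of measured compounds carries this same change, so the series itself gives no measured step to set its size or direction. The step from compound 1 to compound 3 in this assay is expected to be a number 13 percentage points higher from compound 1 to compound 3 (beyond the scatter), a modest weakening that may not exceed the scatter. Compound 3 is therefore expected to give about 25%, in the range 8% to 70%.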

Compound 3, a percentage reported as activity, at one concentration (the size of the read-out at that concentration, not a potency): 9%
For compound 3 the middle estimate is 16 percentage points above the measured one; low and high end bracket the measured number.
By their numbers in this assay, from the lowest: compounds 3, 1 and 2 (each within the scatter of the next).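

In this assay, dimethylamino in place of acetyl on an aromatic carbon, para to a large group, gives a number 3 percentage points lower from compound 1 to compound 3 (within the scatter). Going by these compounds alone, this is the first measured change at this place, and it shows that the strong effect at the tested concentration does not depend on the acetyl carbonyl: a group with no carbonyl, the same heavy-atom count and the same hydrogen-bond acceptor count serves equally well within the scatter. No measured property of either group bears on this result, so nothing can be said about its origin.

Going by these compounds, whether this place also accepts a carboxylic acid, a primary amine or a longer chain remains open. With one concentration and low read-outs throughout, any difference in potency between acetyl and dimethylamino also remains unresolved.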